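The source may report more compounds than this note shows. Statements on the series, on what has been measured and on what is new or still open speak of the compounds shown alone.

For the measured compounds named here, compound 1 `CCOC(=O)/C=C/c1ccncc1-c1ccc2[nH]ccc2c1` is the first of three compounds measured in a functional assay on A549 cells (Homo sapiens) for inhibition, read by sulforhodamine B assay, with a stated time of 72 h (on this read-out lower numbers stand for stronger inhibition of growth and higher numbers for weaker inhibition of growth), where compound 1 gives 7440 nM. Compound 2 `CNC(=O)/C=C/c1ccncc1-c1ccc2c(cnn2C)c1` returns only the limit of this assay, > 10000 nM, and not a number (the limit of > 10000 nM in this assay, at which 1 of the 3 values shown sits). Compound 3 `CNC(=O)CCc1ccncc1-c1ccc2ccccc2c1` gives 10400 nM in this assay; this is the highest of the two numbers, but its gap to compound 1 lies within the scatter, so the two cannot be told apart on this read-out.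

Compound 4 `O=C(O)/C=C/c1ccncc1-c1ccc2ccccc2c1` has not yet been measured. It differs from compound 3 in one place (2-carboxyethenyl in place of 2-(methylcarbamoyl)ethyl on an aromatic carbon). Going by the values given here, no step between two measured compounds isolates this change, so it can only be read against the measured values themselves, which all sit at or above the weakly inhibiting end of this assay. Compound 4 is expected to sit near compound 3 or somewhat higher, with the step of a 1.4-fold higher number from compound 3 to compound 4 (0.16 log units; within the scatter) expected to stay at or just beyond the scatter. Compound 4 is thus estimated at 15000 nM, expected between 5000 nM and 45000 nM, with a fair chance that only a limit is reported.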

Compound 4, concentration for 50% growth inhibition: > 10000 nM
Compound 4 gave a limit, no number; the forecaster's own chance of this, stated with the estimate: 55%; the middle value does not contradict the limit.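

In this assay, for the compounds shown here, compound 4 returns only a limit, > 10000 nM, and not a number, so no step from compound 3 can be read. The compounds shown leave open whether 2-carboxyethenyl in place of 2-(methylcarbamoyl)ethyl changes growth inhibition at all.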